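Tolerance of Host Cells Toward Three Related Compounds

A few compounds are considered here, and "the series" means these few. Any claim that something is new, unique, unknown or untested is made for them only; others in the source may bear on it.

Compound 1, `Nc1nc(NCc2ccccc2)c2ncn(/C=C3/CC3(CO)CO)c2n1`: in an ADME assay on HFF cells (Homo sapiens) for cytotoxicity, with a stated time of 8 days (a lower number here means that less compound is tolerated, a higher number that more compound is tolerated), compound 1 gives > 300000 nM, which is a limit of the assay and not a number.
Compound 2, `CCCCCOc1nc(N)nc2c1ncn2/C=C1/CC1(CO)CO`: in this assay compound 2 gives 259000 nM.

Compound 2 holds the only number shown in this assay; the other value is a limit (the limit of > 300000 nM in this assay, at which 1 of the 2 values shown sits). Among the compounds with values here, the single measured step is an at least 1.1-fold lower number from compound 1 to compound 2 (0.06 log units; that floor lies within the scatter), and its floor lies within the scatter, so it shows no clear movement. Compound 3, `CCCSc1nc(N)nc2c1ncn2/C=C1/CC1(CO)CO`, has not yet been measured. It differs from compound 2 by propylsulfanyl in place of pentyloxy on an aromatic carbon. Within the data shown here, no measured step touches a propylsulfanyl group, so the one step that bears on it is the step from compound 1 to compound 2, which itself did not leave the scatter. Compound 3 is therefore expected to show a step of a 1.2-fold higher number from compound 2 to compound 3 (0.06 log units; within the scatter), that is, none beyond the scatter. Compound 3 is estimated at 300000 nM, with a range from 120000 nM to 700000 nM.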

Compound 3, half-maximal cytotoxic concentration: > 300000 nM
Compound 3 ended at the assay's limit (the forecaster's own chance of this, stated with the estimate: 55%); the middle value lies on the limit itself.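

Within the data shown here, this position, on an aromatic carbon next to the ring nitrogen, now carries a sulfur-linked chain for the first time, and the change from pentyloxy to propylsulfanyl gives an at least 1.1-fold higher number from compound 2 to compound 3 (0.06 log units; that floor lies within the scatter). That floor shows no clear movement in this assay, and the true size of the step stays hidden at the limit. So benzylamino, pentyloxy and propylsulfanyl at this position have so far produced no readable step beyond the scatter, and the step between the two compounds that sit at the limit cannot be read: the limit of > 300000 nM in this assay, at which 2 of the 3 values shown sit.

Going by these compounds, it remains open whether a carboxylic acid, or a longer chain on the sulfur, at this position would move the number beyond the scatter in this assay. On these data alone, how far compound 3 lies past its limit also remains open.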